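A few compounds are considered here, and "the series" means these few. Any claim that something is new, unique, unknown or untested is made for them only; others in the source may bear on it.

Compound 2 `COc1ccc(/C=C/c2cc(OC)cc(OC)c2/C=C/C(=O)c2ccc(F)cc2)cc1` gives 12.2 ug/mL in a functional assay on HepG2 cells (Homo sapiens) for antiproliferative activity, read by MTT assay, with a stated time of 48 h (on this read-out lower numbers stand for stronger inhibition and higher numbers for weaker inhibition), the highest of the two numbers shown; compound 1 `COc1ccc(/C=C/c2cc(OC)cc(OC)c2/C=C/C(=O)c2ccc(N)cc2)cc1` gives 7.5 ug/mL, and a 1.6-fold higher number from compound 1 to compound 2 (0.21 log units; within the scatter) lies within the scatter. Compound 3 `CCN(CC)c1ccc(C(=O)/C=C/c2c(/C=C/c3ccc(OC)cc3)cc(OC)cc2OC)cc1` is not yet measured. It differs from compound 2 by diethylamino in place of fluoro on an aromatic carbon. Among the measured compounds shown here, only the step exchanging amino for fluoro at this aromatic carbon bears on the change, and that step stayed within the scatter; no measured compound carries a diethylamino group, so the direction is uncertain. For compound 3 the expected step is a 1.4-fold lower number from compound 2 to compound 3 (0.13 log units; within the scatter), not beyond the scatter. The estimate for compound 3 is 9 ug/mL, with a range from 4 ug/mL to 20 ug/mL.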

Compound 3, half-maximal inhibitory concentration: 6.3 ug/mL
For compound 3 the middle estimate is 1.4-fold (0.15 log units) above the measured one; the range from low to high includes it.
By their numbers in this assay, from the lowest: compounds 3, 1 and 2 (each within the scatter of the next).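

Diethylamino, with five heavy atoms against the one of fluoro, sits on the aromatic carbon para to a large group without a step beyond the scatter (a 1.9-fold lower number from compound 2 to compound 3 (0.29 log units; within the scatter)). Against amino the step is also small (a 1.2-fold lower number from compound 1 to compound 3 (0.08 log units; within the scatter)). This position therefore accepts a much larger group with no change that can be read, and no measurement on hand explains this.

On these data alone, whether a carboxylic acid or a morpholine here would move the number beyond the scatter stays open. So does whether any change at this position can do so on the shared core.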